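Cutting the sulfur side chain down to bare sulfanyl

The source may report more compounds than this note shows. Statements on the series, on what has been measured and on what is new or still open speak of the compounds shown alone.

Three measured compounds share one core and differ only in the chain carried on the sulfur. In a functional assay on HT cells (Homo sapiens) for antiproliferative activity, read by fluorescence, with a stated time of 72 h (a higher number here means a weaker inhibitor of growth, a lower number a stronger inhibitor of growth), compound 1 `CC(C)c1n[nH]c2c(NCc3ccc(-c4ccccn4)cc3)nc(SCC(O)CN)nc12` gives 55 nM. Compound 2 `CC(C)c1n[nH]c2c(NCc3ccc(-c4ccccn4)cc3)nc(SCC(N)CN)nc12` gives 480 nM, and compound 3 `CC(C)c1n[nH]c2c(NCc3ccc(-c4ccccn4)cc3)nc(SCC(O)CN3CCNCC3)nc12` gives 332 nM. Compound 3 thus stands second highest of the three numbers: it lies within the scatter of compound 2, while compound 1 sits clearly below it, a 6.0-fold higher number from compound 1 to compound 3 (0.78 log units; beyond the scatter). Both changes to the chain that were measured were modest: an 8.7-fold higher number from compound 1 to compound 2 (0.94 log units; beyond the scatter) and a 6.0-fold higher number from compound 1 to compound 3 (0.78 log units; beyond the scatter); between the two weaker compounds there is a 1.4-fold lower number from compound 2 to compound 3 (0.16 log units; within the scatter).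

Compound 4 `CC(C)c1n[nH]c2c(NCc3ccc(-c4ccccn4)cc3)nc(S)nc12` removes the chain altogether: hydrogen in place of 2-hydroxy-3-(piperazin-1-yl)propyl on a sulfur. Going by the values given here, no measured step removes the chain, so nothing shows directly how much of the growth inhibition rests on it. The measured steps show only that reshaping the chain moves the number modestly, with the hydroxy and amino arrangement of compound 1 giving the lowest number. With the bare sulfanyl, the hydroxy and the piperazin-1-yl ring are both gone. Compound 4 is expected to show a step upward beyond the scatter, a 4.5-fold higher number from compound 3 to compound 4 (0.65 log units; beyond the scatter), with wide uncertainty. Compound 4 is estimated at 1500 nM, in a range from 300 nM to 8000 nM.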

Compound 4, concentration for 50% growth inhibition: 2760 nM
Estimate against measurement, compound 4: 1.8-fold (0.26 log units) below; measured number inside the range.
By their numbers in this assay, from the lowest: compound 1; then compounds 3 and 2 (each within the scatter of the next); then compound 4.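

The bare sulfanyl gives the highest number of the four in this assay, so each chain shown on this sulfur goes with stronger growth inhibition than no chain at all, with modest steps for two of them (an 8.3-fold higher number from compound 3 to compound 4 (0.92 log units; beyond the scatter); a 5.8-fold higher number from compound 2 to compound 4 (0.76 log units; beyond the scatter)) and a large one for the 3-amino-2-hydroxypropyl chain (a 50-fold higher number from compound 1 to compound 4 (1.70 log units; beyond the scatter)). The earlier compounds shown here only compared chains with one another, whereas this result sets all three against a baseline and shows that the chain's presence and its exact form both count, though compound 4 still gives a finite number of 2760 nM without any chain. Nothing available here explains why the chains make this difference.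

The compounds shown leave open whether a single methyl on the sulfur, or a plain propyl chain carrying neither hydroxy nor amino, would already lower the number, so the share owed to the chain's carbons and the share owed to its hydroxy and amino groups cannot be separated. Also open, going by these compounds, is how a longer chain ending in an amine would compare with the 3-amino-2-hydroxypropyl chain.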